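The source may report more compounds than this note shows. Statements on the series, on what has been measured and on what is new or still open speak of the compounds shown alone.

Working notes on the series, read in a functional assay on the whole organism with Mus musculus as the target; on this read-out higher numbers stand for an effect only at larger amounts of compound and lower numbers for an effect already at smaller amounts. Compound 2 `COc1cc2c(cc1OC)C(c1ccc([N+](=O)[O-])cc1)=NN=C(S)C2` gives 69.8 umol/kg. Compound 3 `COc1cc2c(cc1OC)C(c1ccc(Cl)cc1)=NNC(=O)C2` gives 75.3 umol/kg, within the scatter of compound 2, although the two structures differ in more than one place. Compound 1 `COc1cc2c(cc1OC)C(c1cccc(N)c1)=NN=C(S)C2` gives 9.1 umol/kg, a lower number than that of compound 2 and beyond the scatter. Compound 2 therefore stands level with compound 3, at the upper end of the numbers in hand, with compound 1 well apart from the pair.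

Compound 4 `COc1cc2c(cc1OC)C(c1ccccc1)=NN=C(S)C2` has not yet been measured. It departs from compound 2 by one change: hydrogen in place of nitro on an aromatic carbon. Among the measured compounds shown here, no measured pair isolates this change, so any forecast is weakly anchored. For the measured compounds named here, the only guide is compound 1, which has no nitro group, carries an amino group instead, and reads 9.1 umol/kg. On that slim basis a lower number than that of compound 2 is expected, though not one as low as that of compound 1. The expected size is a modest 2.3-fold lower number from compound 2 to compound 4 (0.37 log units; beyond the scatter). Compound 4 is estimated at 30 umol/kg, with an expected range of 11 umol/kg to 80 umol/kg.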

Compound 4, dose for half-maximal effect: 15 umol/kg
Compound 4: the middle estimate sits 2.0-fold (0.30 log units) above what was measured, within the range that was stated.
By their numbers in this assay, from the lowest: compounds 1 and 4 (each within the scatter of the next); then compounds 2 and 3 (each within the scatter of the next).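

Hydrogen in place of nitro on this aromatic carbon, para to a large group, gives a 4.7-fold lower number from compound 2 to compound 4 (0.67 log units; beyond the scatter) in this assay as the first single-change reading at this position, and it shows that nitro here goes with effect only at larger amounts of compound. Hydrogen in place of amino gives a 1.6-fold higher number from compound 1 to compound 4 (0.22 log units; within the scatter) and so leaves compound 1 and compound 4 level; the amino group therefore shows no separation from the ring that carries neither group, and the wide gap between compound 1 and compound 2 now lines up with the nitro change instead of with any gain from amino. No measurement in hand bears on what lies behind either step.

The compounds shown leave open whether a nitrile, a carboxylic acid or a methoxy group on this same aromatic carbon would read like nitro or like hydrogen. They also leave open whether an amino group on this same carbon would stay level with hydrogen, as the amino group of compound 1 does.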